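Swapping the Azole on the Unmethylated Core

A few compounds are considered here, and "the series" means these few. Any claim that something is new, unique, unknown or untested is made for them only; others in the source may bear on it.

Of the compounds shown here, three have been measured in a functional assay for inhibition of sodium/hydrogen exchanger (Oryctolagus cuniculus); on this read-out higher numbers stand for weaker inhibition and lower numbers for stronger inhibition. Compound 1 `Cc1cc(-n2ccnc2)c(S(C)(=O)=O)cc1C(=O)N=C(N)N` gives 23 nM, compound 3 `Cc1cc(-n2cccn2)c(S(C)(=O)=O)cc1C(=O)N=C(N)N` gives 25 nM, and compound 2 `CS(=O)(=O)c1cc(C(=O)N=C(N)N)ccc1-n1cccn1` gives 160 nM. Compound 2 therefore stands at the highest of the three numbers, and the gap to its nearest neighbour is a 6.4-fold lower number from compound 2 to compound 3 (0.81 log units; beyond the scatter), a change that turns on the methyl alone. Compound 4 `CS(=O)(=O)c1cc(C(=O)N=C(N)N)ccc1-n1ccnc1` differs from compound 2 by 1H-imidazol-1-yl in place of 1H-pyrazol-1-yl on an aromatic carbon. Within the data shown here, the one measured step that bears on this swap of azoles is a 1.1-fold higher number from compound 1 to compound 3 (0.04 log units; within the scatter), which lay within the scatter. On that evidence the exchange is expected to shift the number little in this assay. The expected step is a 1.1-fold lower number from compound 2 to compound 4 (0.03 log units; within the scatter). Compound 4 is accordingly estimated to give about 150 nM, within a range of 70 nM to 320 nM.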

Compound 4, half-maximal inhibitory concentration: 150 nM
Compound 4: the middle estimate sits on the measured number at the digits printed; the range from low to high includes it.
By their numbers in this assay, from the lowest: compounds 1 and 3 (each within the scatter of the next); then compounds 4 and 2 (each within the scatter of the next).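

On the core without the methyl, as on the methylated one, the two azoles on this aromatic carbon, ortho to a methylsulfonyl group, are not told apart in this assay. Here the exchange gives a 1.1-fold lower number from compound 2 to compound 4 (0.03 log units; within the scatter) and stays within the scatter on both cores: the same change on two cores in this assay, a 1.1-fold higher number (0.04 log units; within the scatter) from compound 1 to compound 3 and a 1.1-fold higher number (0.03 log units; within the scatter) from compound 4 to compound 2, 1.0-fold (0.01 log units) apart, within the scatter of two such steps. The methyl step also recurs with the imidazole in place, with a 6.5-fold higher number from compound 1 to compound 4 (0.81 log units; beyond the scatter) matching the step seen with the pyrazole: the same change on two cores in this assay, a 6.4-fold lower number (0.81 log units; beyond the scatter) from compound 2 to compound 3 and a 6.5-fold lower number (0.81 log units; beyond the scatter) from compound 4 to compound 1, 1.0-fold (0.01 log units) apart, within the scatter of two such steps. On these data alone, whether an amine or a carboxylic acid at this position would hold the number remains open. So does the outcome of replacing the methyl with an ethyl group.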